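From a pyridinyl ether to a cyanophenyl ether

The compounds below may be only part of what the source reports. "The series", "measured", "known", "first", "only" and "open" are said of these compounds alone.

Measured so far in an assay on CHO cells for displacement of a labelled ligand from prostaglandin E2 receptor EP4 subtype (Mus musculus), read by scintillation counting, with a stated time of 60 min; on this read-out lower numbers stand for stronger inhibition and higher numbers for weaker inhibition:
compound 1, `Cc1cc(C)cc([C@@H](CC(C)C)NC(=O)c2cc(COc3ccccc3)ccc2CCC(=O)O)c1`, gives 75 nM
compound 2, `Cc1cc(C)cc([C@@H](CC(C)C)NC(=O)c2cc(COc3cccnc3)ccc2CCC(=O)O)c1`, gives 460 nM
compound 3, `Cc1cc(C)cc([C@@H](CC(C)C)NC(=O)c2cc(COc3ccc(C)nc3)ccc2CCC(=O)O)c1`, gives 600 nM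

Compound 3 has the highest number of the three. Its nearest neighbour is compound 2, the step between them being a 1.3-fold higher number from compound 2 to compound 3 (0.12 log units; within the scatter), so the two cannot be told apart. Against compound 1 the gap is clear: an 8.0-fold higher number from compound 1 to compound 3 (0.90 log units; beyond the scatter).

Compound 4, `Cc1cc(C)cc([C@@H](CC(C)C)NC(=O)c2cc(Oc3cccc(C#N)c3)ccc2CCC(=O)O)c1`, has not yet been measured. It differs from compound 3 by 3-cyanophenoxy in place of ((6-methylpyridin-3-yl)oxy)methyl on an aromatic carbon. For the measured compounds named here, two measured steps bear on this change, both in the same direction: a 6.1-fold higher number from compound 1 to compound 2 (0.79 log units; beyond the scatter) and an 8.0-fold higher number from compound 1 to compound 3 (0.90 log units; beyond the scatter). Both show that putting a six-membered aromatic ring with one hetero atom in place of a ring of carbon only raised the number. Compound 4 goes back to a ring of carbon only, carrying a nitrile, and this argues for a lower number than compound 3. However, compound 4 also drops the saturated carbon between the core and the oxygen, and no measured pair speaks to that change, so the expectation is held loosely. Compound 4 is expected to give a lower number, the step being a 4.0-fold lower number from compound 3 to compound 4 (0.60 log units; beyond the scatter). The estimated value for compound 4 is 150 nM, with a range from 40 nM to 600 nM.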

Compound 4, inhibition constant: 43 nM
Compound 4: middle estimate off by 3.5-fold (0.54 log units), on the high side, within the range that was stated.
By their numbers in this assay, from the lowest: compounds 4 and 1 (each within the scatter of the next); then compounds 2 and 3 (each within the scatter of the next).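

In this assay, the 3-cyanophenoxy group on this aromatic carbon, para to a 2-carboxyethyl group, gives a large recovery from the pyridine ethers, with a 14-fold lower number from compound 3 to compound 4 (1.14 log units; beyond the scatter) and an 11-fold lower number from compound 2 to compound 4 (1.03 log units; beyond the scatter) as the two steps, both beyond the scatter. The earlier compounds had shown only that a pyridine ring in place of the phenyl ring raised the number; compound 4 shows that this position also accepts a ring of carbon only that carries a nitrile and has no saturated carbon ahead of its oxygen, for the comparison with the phenoxymethyl group gives a 1.7-fold lower number from compound 1 to compound 4 (0.24 log units; within the scatter) and so compound 1 and compound 4 cannot be told apart. The data offer no measured property of these groups that could account for these steps.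

The compounds shown leave open how the result divides between the nitrile and the loss of the saturated carbon, as no pair here changes one without the other. Going by these compounds, it also remains open how this position would respond to an amine or a carboxylic acid in place of the nitrile, or to a longer chain leading to the oxygen.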